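The compounds below may be only part of what the source reports. "The series", "measured", "known", "first", "only" and "open" are said of these compounds alone.

Measured compounds:
compound 1, `COc1cccc(/C=C/C(=O)c2sc(Nc3cccc(C)c3)nc2C)c1`, a functional assay on NCI-H460 cells (Homo sapiens) for cytotoxicity, read by MTT assay; on this read-out higher numbers stand for weaker inhibition and lower numbers for stronger inhibition: > 25000 nM
compound 2, `COc1cccc(/C=C/C(=O)c2sc(Nc3ccccc3C)nc2C)c1`, this assay: > 25000 nM

Compound 2, `COc1cccc(/C=C/C(=O)c2sc(Nc3ccccc3C)nc2C)c1`, reaches only a limit of this assay, > 25000 nM, so its true value is not known as a number. Compound 1 likewise sits at a limit in this assay, > 25000 nM. The step from compound 1 to compound 2, a step that the two limits leave unreadable from compound 1 to compound 2, is therefore unreadable; both values sit at the limit of > 25000 nM in this assay, at which 2 of the 2 values shown sit.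

Compound 3, `Cc1ccccc1Nc1nc(C)c(C(=O)/C=C/c2ccccc2Cl)s1`, differs from compound 2 in one place: 2-chlorophenyl in place of 3-methoxyphenyl on a double-bonded chain carbon bound to a double-bonded chain carbon. Among the measured compounds shown here, no measured step touches this position, and the one measured step gives no readable size. What can be said is that both measured compounds sit at a limit, so compound 2 provides only a floor of weakness to start from.

Compound 3 is estimated at 30000 nM, with a range from 8000 nM to 100000 nM, most likely again a limit. The step from compound 2 to compound 3 is expected to be a step that the limit leaves unreadable from compound 2 to compound 3, not readable beyond the scatter.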

Compound 3, half-maximal inhibitory concentration: > 25000 nM
Compound 3: a limit, no number (the forecaster's own chance of this, stated with the estimate: 70%); the middle value is on the limit's open side.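

In this assay compound 3 gives > 25000 nM, which is a limit and not a number. The step between compound 2 and compound 3 cannot be read, as both sit at one limit: the limit of > 25000 nM in this assay, at which 3 of the 3 values shown sit. The compounds shown leave open what true value any of them has, and whether either change shifts it.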